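A Longer Chain and a Larger Ring for Compound 4

A few compounds are considered here, and "the series" means these few. Any claim that something is new, unique, unknown or untested is made for them only; others in the source may bear on it.

Compound 1 `CCCCc1oc2ccccc2c1C(=O)c1ccc(OCC(=O)N2CCCC2)cc1` carries a (pyrrolidin-1-yl)carbonyl group on a saturated chain carbon bound to an oxygen on an aromatic ring of the shared core. In a functional assay on MDA-MB-231 cells (Homo sapiens) for antiproliferative activity, read by MTT assay, with a stated time of 24 h (on this read-out higher numbers stand for weaker inhibition and lower numbers for stronger inhibition), compound 1 gives only a limit, > 50000 nM. Its two companions map the remaining ground. Compound 2 `CCCCc1oc2ccccc2c1C(=O)c1ccc(OCC(=O)Nc2cccc(OC)c2)cc1` likewise reaches only a limit in this assay, > 50000 nM. Compound 3 `CCCCc1oc2ccccc2c1C(=O)c1ccc(OCC(=O)N[C@H](C)c2ccccc2)cc1` gives 39000 nM in this assay. The step of an at least 1.2-fold lower number from compound 1 to compound 3 (0.10 log units; that floor lies within the scatter) and the step of an at least 1.2-fold lower number from compound 2 to compound 3 (0.10 log units; that floor lies within the scatter) are floors only, and the step that the two limits leave unreadable from compound 1 to compound 2 cannot be read at all, since (the limit of > 50000 nM in this assay, at which 2 of the 3 values shown sit).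

Compound 4 `CCCCc1oc2ccccc2c1C(=O)c1ccc(OCCCC(=O)N2CCCCC2)cc1` differs from compound 1 by 2-((piperidin-1-yl)carbonyl)ethyl in place of (pyrrolidin-1-yl)carbonyl on a saturated chain carbon bound to an oxygen on an aromatic ring. Going by the values given here, none of the measured steps touches either the length of the chain or the size of the saturated ring, so they offer no direction for this change, and every value shown sits at or near the limit. Compound 4 is therefore expected to give 60000 nM in this assay, within a range from 30000 nM to 150000 nM. The step that the limit leaves unreadable from compound 1 to compound 4 that this estimate means stays within the scatter, and the likeliest outcome is that this assay again reports only a limit.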

Compound 4, half-maximal inhibitory concentration: 36000 nM
Compound 4: middle estimate off by 1.7-fold (0.22 log units), on the high side; low and high end bracket the measured number.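

Compound 4 joins compound 3 in giving a number rather than a limit in this assay, so moving from ((pyrrolidin-1-yl)carbonyl)methyl to 3-((piperidin-1-yl)carbonyl)propyl at this place on the shared core yields a readable result. As far as these compounds go, how much the change shifts the read-out stays unknown, with an at least 1.3-fold lower number from compound 1 to compound 4 (0.14 log units; that floor lies within the scatter) and an at least 1.3-fold lower number from compound 2 to compound 4 (0.14 log units; that floor lies within the scatter) both floors only, because these comparisons rest on a limit: the limit of > 50000 nM in this assay, at which 2 of the 4 values shown sit. Going by these compounds alone, the one comparison between two true numbers is a 1.1-fold lower number from compound 3 to compound 4 (0.03 log units; within the scatter), so the longer chain ending in a piperidine amide and the shorter one ending in (1-phenylethyl)carbamoyl cannot be told apart here.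

The chain and the ring changed together in compound 4, which leaves open what each contributes; 3-((pyrrolidin-1-yl)carbonyl)propyl and ((piperidin-1-yl)carbonyl)methyl would separate the two. Also open, from the compounds shown here alone, is whether other groups at the end of this chain, such as a morpholine amide or a free carboxylic acid, would move the number clearly beyond the scatter.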